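Chain extension in a carbamate series: a step repeated

The source may hold more compounds than are shown below. What is called first, only, known or untested is meant among the compounds shown, and "the series" means these compounds.

Measured so far in an assay on microsomes from intestine for inhibition of acyl-CoA:cholesterol acyltransferase (Oryctolagus cuniculus); on this read-out lower numbers stand for stronger inhibition and higher numbers for weaker inhibition:
compound 1, `CCCCCCCCCCCCOC(=O)NC(=O)Oc1c(C(C)C)cccc1C(C)C`, gives 21 nM
compound 2, `CCCCCCCCCCCCCOC(=O)NC(=O)Oc1c(C(C)C)cccc1C(C)C`, gives 9 nM
compound 3, `CCCCCCCCCCSC(=O)NC(=O)Oc1c(C(C)C)cccc1C(C)C`, gives 130 nM

Compounds 1 and 2 share a core and differ in one place, (methyl in place of hydrogen on a saturated chain carbon, ten or more bonds along the chain from an oxygen next to a carbonyl group), and this change made a modest step in this assay, a 2.3-fold lower number from compound 1 to compound 2 (0.37 log units; beyond the scatter). Compound 3 has the highest of the three numbers; how its core differs from the core of compound 1 is not broken down here.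

Compound 4, `CCCCCCCCCCCSC(=O)NC(=O)Oc1c(C(C)C)cccc1C(C)C`, is not yet measured. It is made from compound 3 by methyl in place of hydrogen on a saturated chain carbon, ten or more bonds along the chain from a sulfur. This is the same kind of change as from compound 1 to compound 2, but the place differs, as the two descriptions of the differences show: the chain counts from a sulfur in the one case and from an oxygen next to a carbonyl group in the other. Going by the values given here, on the single earlier step alone, a similar modest lowering is expected for compound 4, a 2.2-fold lower number from compound 3 to compound 4 (0.34 log units; beyond the scatter), with the estimate placed at 60 nM and the expected range running from 25 nM to 150 nM.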

Compound 4, half-maximal inhibitory concentration: 210 nM
For compound 4 the middle estimate is 3.5-fold (0.54 log units) below the measured one, outside the stated range (above it).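

In this assay, methyl in place of hydrogen on the saturated chain carbon counted from a sulfur gives a 1.6-fold higher number from compound 3 to compound 4 (0.21 log units; within the scatter), so this step does not tell the two compounds apart. Set beside the step on the core of compound 1, the same change does not carry over as one fixed step between these two cores: the same change on two cores in this assay, a 2.3-fold lower number (0.37 log units; beyond the scatter) from compound 1 to compound 2 and a 1.6-fold higher number (0.21 log units; within the scatter) from compound 3 to compound 4, 3.8-fold (0.58 log units) apart, beyond the scatter of two such steps

This rests on a single pair on each core, so it shows that the step from the one core is a poor guide to the other here, but it does not show what in the two cores sets the steps apart, nor how either series behaves at other chain lengths.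

Still open, going by these compounds, is whether a longer chain on the core of compound 3 gives a step beyond the scatter or continues to leave the number unresolved. Also open, on these data alone, is whether a longer chain on the core of compound 1 extends the step seen there, and whether a branched chain or a chain ending in an amine behaves alike on both cores.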